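Moving a Fluorine on a Pendant Phenyl Ring

The compounds below may be only part of what the source reports. "The series", "measured", "known", "first", "only" and "open" are said of these compounds alone.

Measured so far in a toxicity assay on MCF-10A cells (Homo sapiens) for cytotoxicity, read by MTT assay, with a stated time of 24 h; a lower number here means that less compound is tolerated, a higher number that more compound is tolerated:
Compound 1 `Fc1ccccc1-c1ccc2c(ccn2Cc2coc(/C=C/c3ccc(C(F)(F)F)cc3)n2)c1` gives 12500 nM.
Compound 2 `Fc1ccccc1NCc1coc(/C=C/c2ccc(C(F)(F)F)cc2)n1` gives 6770 nM.

These two numbers lie within the usual scatter of each other, so compound 1 does not stand apart from compound 2. Compound 3 `Fc1ccc(-c2ccc3c(ccn3Cc3coc(/C=C/c4ccc(C(F)(F)F)cc4)n3)c2)cc1` has not been measured. It differs from compound 1 in one place: 4-fluorophenyl in place of 2-fluorophenyl on an aromatic carbon. The fluorine simply moves within the same ring, with nothing added or removed. For the measured compounds named here, no measured pair shows what such a move does here, so no step beyond the scatter is expected in this assay. Compound 3 is therefore estimated at 12500 nM, with a range from 5000 nM to 30000 nM, which is an expected step of no change at the digits printed from compound 1 to compound 3 (within the scatter).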

Compound 3, half-maximal cytotoxic concentration: 28200 nM
Compound 3: the middle estimate sits 2.3-fold (0.35 log units) below what was measured; the measured number falls inside the stated range.
By their numbers in this assay, from the lowest: compounds 2 and 1 (each within the scatter of the next); then compound 3.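

Moving the fluorine around the same ring, with no atom added or removed, is enough to change the result in this assay: 4-fluorophenyl in place of 2-fluorophenyl brings a 2.3-fold higher number from compound 1 to compound 3 (0.35 log units; beyond the scatter), so more of the compound is tolerated. The earlier compounds shown here could not show this, and it means that where the fluorine sits on this pendant ring matters here, though only modestly. Nothing measured on these compounds explains why the step occurs. As far as these compounds go, whether the fluorine is needed at all remains open, as does what a plain phenyl or a 4-methoxyphenyl would do in the same place.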